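A few compounds are considered here, and "the series" means these few. Any claim that something is new, unique, unknown or untested is made for them only; others in the source may bear on it.

Measured so far:
Compound 1 `O=[N+]([O-])c1cn2c(n1)OC[C@@H](NCc1ccc(OC(F)(F)F)cc1F)C2` — in an in vitro ADME assay on the whole organism (microsomes, liver, Mus musculus) for metabolic stability, read by LC-MS, with a stated time of 24 h, at a dose of 5 mg/kg by the intravenous route (on this read-out higher numbers stand for fast clearance and lower numbers for slow clearance), compound 1 gives 95.6 mL.min-1.g-1.
Compound 2 `O=[N+]([O-])c1cn2c(n1)OC[C@@H](NCc1ccc(OC(F)(F)F)c(O)c1)C2` — in this assay compound 2 gives 61.9 mL.min-1.g-1.

Among these two numbers compound 1 stands highest, yet its only neighbour, compound 2, sits just a little lower, and that gap lies within the usual scatter of repeated measurements; the two values are best read as alike. Compound 3 `O=[N+]([O-])c1cn2c(n1)OC[C@@H](NCc1ccc(OC(F)(F)F)cc1O)C2` has not yet been measured in this assay. It differs from compound 1 in one place: hydroxy in place of fluoro on an aromatic carbon. Among the measured compounds shown here, no step between measured compounds carries this exact change, so the expectation rests only on what the two values show. Compound 2 also carries a hydroxy and gives a number not separable from that of compound 1 in this assay, so the step expected here is a 1.3-fold lower number from compound 1 to compound 3 (0.12 log units; within the scatter), small, if anything toward a slower reading, and most likely not beyond the scatter. Compound 3 is accordingly estimated at 72 mL.min-1.g-1, with a range from 36 mL.min-1.g-1 to 145 mL.min-1.g-1.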

Compound 3, intrinsic clearance in microsomes: 96.9 mL.min-1.g-1
Estimate against measurement, compound 3: 1.3-fold (0.13 log units) below; the range from low to high includes it.
By their numbers in this assay, from the lowest: compounds 2, 1 and 3 (each within the scatter of the next).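

Placing hydroxy in place of fluoro on this aromatic carbon, ortho to a large group and meta to a trifluoromethoxy group, gives a 1.0-fold higher number from compound 1 to compound 3 (0.01 log units; within the scatter) in this assay, and this is the first pair in the series that isolates the exchange in one place. At this position, then, the two groups cannot be told apart on this read-out, even though the hydroxy brings one hydrogen-bond donor and one hydrogen-bond acceptor where the fluoro counts neither, so that difference in count goes with no step beyond the scatter in this pair. Nothing measured here bears on why the two groups read alike.

Among the compounds shown here, whether a different group on this aromatic carbon, such as an amine, a methoxy or a chlorine, would move the clearance reading beyond the scatter remains open, since fluoro and hydroxy are the only two groups compared here in one place. As far as these compounds go, it is also open whether the same exchange would read alike on another carbon of this ring, because this single pair speaks for this position alone.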